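A few compounds are considered here, and "the series" means these few. Any claim that something is new, unique, unknown or untested is made for them only; others in the source may bear on it.

Among the compounds with values here, compound 1, with the structure `Cc1cccc(Cn2c(CN3CCN(C(=O)CC(C)C)CC3)nc3ccccc32)c1`, has the higher of the two numbers measured so far. In an assay on isolated protein for inhibition of aldehyde dehydrogenase 1A1 (Homo sapiens), read by spectrophotometry, tested at 10 uM (a higher number here means more inhibition at the concentration tested (going by the name of the read-out), a lower number less inhibition), compound 1 gives 71.4%. Within the data shown here, the only other measured compound, compound 2, with the structure `O=C(C1CC1)N1CCN(Cc2nc3ccccc3n2Cc2ccc(Cl)cc2)CC1`, gives 56.6% in this assay, a gap that lies beyond the usual scatter. Among the measured compounds shown here, the two measured compounds differ from each other in more than one place, so no single step between them can be isolated.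

Compound 3, with the structure `Cc1cccc(Cn2c(CN3CCN(C(=O)c4ccc(F)cc4)CC3)nc3ccccc32)c1`, has not been measured. It differs from compound 1 in one place: 4-fluorophenyl in place of isobutyl on a carbonyl carbon. Put another way, the isobutylcarbonyl of compound 1 becomes a (4-fluorophenyl)carbonyl in compound 3, while the rest of the shared core is unchanged.

For the measured compounds named here, no measured pair shows this change, so the expectation rests on compound 1 alone. The step from compound 1 to compound 3 is expected to be small, a number 1.4 percentage points lower from compound 1 to compound 3 (within the scatter), not clearly beyond the scatter in either direction. Compound 3 is therefore expected to give about 70% in this assay, within a range from 48% to 90%.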

Compound 3, a percentage reported as inhibition, at one concentration (the size of the read-out at that concentration, not a potency): 27.1%
Estimate against measurement, compound 3: 42.9 percentage points above, outside the stated range (below it).
By their numbers in this assay, from the lowest: compound 3; then compound 2; then compound 1.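

In this assay the group on the carbonyl carbon proves able to change the result substantially: there is a number 44.3 percentage points lower from compound 1 to compound 3 (beyond the scatter), something the two earlier compounds could not show, as they differ in more than one place. This single change swaps an isobutyl with no ring for a 4-fluorophenyl with a six-membered aromatic ring and more heavy atoms, while the counts of hydrogen-bond donors and acceptors and the net charge stay the same, so the large step comes without any change in those counts. No measurement available here accounts for the drop, so its cause remains unknown.

The compounds shown do not separate the contribution of the aromatic ring from that of the fluorine, a question that a plain phenyl on the same carbonyl carbon could address, while a cyclohexyl would test a ring that is not aromatic. They also leave open whether a longer carbon chain in place of isobutyl would keep the number of compound 1, and whether the same swap would have a similar effect on a different core.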